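A Dichlorophenyl Amide After a Flat Series

This account rests on a few compounds, and the source may have more. Where it says the series, first, only, none or still open, it means among the compounds named here.

In a functional assay on SK-BR-3 cells (Homo sapiens) for antiproliferative activity, read by MTT assay, with a stated time of 72 h (on this read-out lower numbers stand for stronger inhibition and higher numbers for weaker inhibition), compound 1 `CCN1CCN(c2cc(C)c3cc(NC(=O)c4ccccc4C)ccc3n2)CC1` gives 29200 nM, compound 2 `CCN1CCN(c2cc(C)c3cc(NC(=O)c4ccccc4Br)ccc3n2)CC1` gives 39200 nM and compound 3 `CCN1CCN(c2cc(C)c3cc(NC(=O)c4cccc(F)c4)ccc3n2)CC1` gives 24900 nM. All three numbers lie within the usual scatter of one another, so compound 3 is not separated from the other two. Compound 4 `CCN1CCN(c2cc(C)c3cc(NC(=O)c4ccc(Cl)c(Cl)c4)ccc3n2)CC1` carries 3,4-dichlorophenyl in place of 3-fluorophenyl on a carbonyl carbon. Going by the values given here, the steps that bear on this change are those that alter the group on the carbonyl carbon: a 1.2-fold lower number from compound 1 to compound 3 (0.07 log units; within the scatter) and a 1.6-fold lower number from compound 2 to compound 3 (0.20 log units; within the scatter). The remaining measured step, a 1.3-fold higher number from compound 1 to compound 2 (0.13 log units; within the scatter), is similarly small. Among the compounds with values here, none of the measured compounds carries the 3,4-dichlorophenyl group, so the data do not test it directly. No step beyond the scatter is therefore expected in this assay, and no direction is favoured. The expected change is a 1.0-fold lower number from compound 3 to compound 4 (0.02 log units; within the scatter). Compound 4 is estimated at 24000 nM, with an expected range of 11000 nM to 52000 nM.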

Compound 4, half-maximal inhibitory concentration: 2160 nM
Compound 4: middle estimate off by 11-fold (1.05 log units), on the high side, and the stated range ends above it.
By their numbers in this assay, from the lowest: compound 4; then compounds 3, 1 and 2 (each within the scatter of the next).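

In this assay the change to 3,4-dichlorophenyl on a carbonyl carbon brings a 12-fold lower number from compound 3 to compound 4 (1.06 log units; beyond the scatter) and a 14-fold lower number from compound 1 to compound 4 (1.13 log units; beyond the scatter) and an 18-fold lower number from compound 2 to compound 4 (1.26 log units; beyond the scatter) so compound 4 stands clear of the other three. The group at this place is therefore not without consequence for the read-out, although 2-methylphenyl, 2-bromophenyl and 3-fluorophenyl could not be told apart there. Nothing available explains the size of this step.

The compounds shown leave open whether a single chlorine would carry the step, as 3-chlorophenyl or 4-chlorophenyl would show, or whether both are needed. They also leave open whether other groups at this place, such as 3,4-dimethylphenyl or 3,4-dimethoxyphenyl, would give a comparable number.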